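A methyl on the core of compound 1

This account rests on a few compounds, and the source may have more. Where it says the series, first, only, none or still open, it means among the compounds named here.

Compound 1 `Nc1oncc1-c1ccccc1`: 0%
Compound 2 `CNc1oncc1-c1ccccc1`: 0.3%

These numbers come from an ADME assay on blood (Homo sapiens) for metabolic stability, read by LC-MS, with a stated time of 2 h, tested at 0.5 mM (a higher number here means that more of the compound is left, a lower number that less of the compound is left), and they show almost nothing left. Compound 1 gives 0% and thus stands level with compound 2 within the scatter. Compound 3 `Cc1noc(N)c1-c1ccccc1` is still unmeasured and keeps the core of compound 1 with one change, (methyl in place of hydrogen on an aromatic carbon), a methyl in place of hydrogen on an aromatic carbon, next to the ring nitrogen. For the measured compounds named here, the one measured step is a number 0.3 percentage points higher from compound 1 to compound 2 (within the scatter) and it puts a methyl on a nitrogen instead, so it says little about this place. Going by the values given here, no measured step covers this change, so its size is uncertain. Compound 1 has no room to fall, which leaves only an upward move possible. The expected step is a number 20 percentage points higher from compound 1 to compound 3 (beyond the scatter) with wide uncertainty. For compound 3 the estimated value is 20% with an expected range from 0% to 80% in four of five measurements.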

Compound 3, percent of the compound remaining: 84%
Beside the measured number, compound 3's estimate is 64 percentage points below it, and the stated range ends below it.
By their numbers in this assay, from the lowest: compounds 1 and 2 (each within the scatter of the next); then compound 3.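

In this assay, the aromatic carbon next to the ring nitrogen proves highly sensitive to substitution: methyl in place of hydrogen at this position gives a number 84 percentage points higher from compound 1 to compound 3 (beyond the scatter) on the core of compound 1. The earlier methyl on a nitrogen gave only a number 0.3 percentage points higher from compound 1 to compound 2 (within the scatter) and so gave no sign that a change of this size could occur elsewhere on the core. No measurement shown here explains how this methyl leaves so much more of the compound remaining.

As far as these compounds go, it remains open whether the gain is specific to methyl or would also appear with a longer chain such as ethyl, or with a chlorine atom, at the same carbon. Also open, from the compounds shown here alone, is whether a methyl on the nitrogen would shift the number once this carbon already carries a methyl.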